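Cyclopropyl in place of cyclohexyl: notes on the series

This account rests on a few compounds, and the source may have more. Where it says the series, first, only, none or still open, it means among the compounds named here.

Measured so far in a functional assay (aorta) with Rattus norvegicus as the target (on this read-out higher numbers stand for weaker inhibition and lower numbers for stronger inhibition), are two compounds:
compound 1 `CCCCCN(CCCCC)CCCOc1ccc(S(=O)(=O)c2c(C(C)C)cn3ccccc23)cc1` gives 89.6 nM in this series
compound 2 `CCCCN(CCCC)CCCOc1ccc(S(=O)(=O)c2c(C3CCCCC3)cn3ccccc23)cc1` gives 4070 nM in this series

Compound 2 holds the higher of the two numbers, beyond the scatter of compound 1, and is the weaker inhibitor of the pair. Compound 3 `CCCCN(CCCC)CCCOc1ccc(S(=O)(=O)c2c(C3CC3)cn3ccccc23)cc1` is still unmeasured. It carries cyclopropyl in place of cyclohexyl on an aromatic carbon. Among the measured compounds shown here, no measured pair isolates this change in this assay so any expectation is loose. Compound 2 differs from compound 1 in more than one place, yet the value of compound 1 (89.6 nM) shows that the shared core can reach far lower numbers. A large estimated step (a 20-fold lower number from compound 2 to compound 3 (1.31 log units; beyond the scatter)) towards stronger inhibition and beyond the scatter is therefore expected. For compound 3 the expected value is 200 nM with an estimated range of 50 nM to 900 nM as the likely span.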

Compound 3, half-maximal inhibitory concentration: 10.9 nM
Estimate against measurement, compound 3: 18-fold (1.26 log units) above; the whole stated range lies above it.
By their numbers in this assay, from the lowest: compound 3; then compound 1; then compound 2.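

In this assay, the group on this aromatic carbon, two ring bonds from the ring nitrogen, is now shown to matter by itself: cyclopropyl in place of cyclohexyl gives a 370-fold lower number from compound 2 to compound 3 (2.57 log units; beyond the scatter), with the rest of the structure unchanged. Compound 1 and compound 2 differ in more than one place, so they could not assign any part of their gap to this position, whereas this single change gives a large step towards stronger inhibition. Nothing available explains the size of this step.

Open, going by these compounds, is how the read-out follows the substituent between and beyond these two rings, for example with cyclobutyl, cyclopentyl or an open chain such as ethyl. Also open, on these data alone, is whether the same change gives a step of similar size when the amine carries the pentyl chains of compound 1.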